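This account rests on a few compounds, and the source may have more. Where it says the series, first, only, none or still open, it means among the compounds named here.

The measured compounds:
compound 1, `C/C=C1/[C@H](O[C@@H]2O[C@H](CO)[C@@H](O)[C@H](O)[C@H]2O)OC=C(C(=O)O)[C@H]1CC(=O)OC`, > 20000 nM
compound 2, `C/C=C1/[C@H](O[C@@H]2O[C@H](CO)[C@@H](O)[C@H](O)[C@H]2O)OC=C(C(=O)OC)[C@H]1CC(=O)OCc1ccc2c(c1)OCCO2`, > 15000 nM
compound 3, `C/C=C1/[C@H](O[C@@H]2O[C@H](COC(C)=O)[C@@H](OC(C)=O)[C@H](OC(C)=O)[C@H]2OC(C)=O)OC=C(C(=O)OC)[C@H]1CC(=O)OCCC(C)C`, > 15000 nM

Of the compounds shown here, three that share one core have been tested in a functional assay on SK-BR-3 cells (Homo sapiens) for antiproliferative activity, read by MTT assay, with a stated time of 72 h; on this read-out lower numbers stand for stronger inhibition and higher numbers for weaker inhibition. Compound 1 `C/C=C1/[C@H](O[C@@H]2O[C@H](CO)[C@@H](O)[C@H](O)[C@H]2O)OC=C(C(=O)O)[C@H]1CC(=O)OC` reaches only a limit of the assay there, > 20000 nM. Compound 2 `C/C=C1/[C@H](O[C@@H]2O[C@H](CO)[C@@H](O)[C@H](O)[C@H]2O)OC=C(C(=O)OC)[C@H]1CC(=O)OCc1ccc2c(c1)OCCO2` likewise gives only a limit, > 15000 nM. Compound 3 `C/C=C1/[C@H](O[C@@H]2O[C@H](COC(C)=O)[C@@H](OC(C)=O)[C@H](OC(C)=O)[C@H]2OC(C)=O)OC=C(C(=O)OC)[C@H]1CC(=O)OCCC(C)C` also stops at a limit, > 15000 nM. Among the measured compounds shown here, since none of the three yields a number, no step between them can be measured. Compound 2 stands at the limit of > 15000 nM in this assay, at which 2 of the 3 values shown sit, a position it shares with compound 3, while compound 1 sits at the limit of > 20000 nM in this assay, at which 1 of the 3 values shown sits.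

Compound 4 `C/C=C1/[C@H](O[C@@H]2O[C@H](CO)[C@@H](O)[C@H](O)[C@H]2O)OC=C(C(=O)OC)[C@H]1CC(=O)OCCC1CCCCC1` has not yet been measured. It differs from compound 2 in one place: cyclohexylmethyl in place of 2,3-dihydro-1,4-benzodioxin-6-yl on a saturated chain carbon bound to an oxygen next to a carbonyl group. For the measured compounds named here, with no measured step to lean on, the size of the step cannot be read from the numbers. The three compounds already tested all ended at a limit, and nothing among them points to the new group turning this around. Compound 4 is therefore expected to reach only a limit again, estimated at 20000 nM, within 8000 nM to 50000 nM. The expected step that the limit leaves unreadable from compound 2 to compound 4 is thus none beyond the scatter.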

Compound 4, half-maximal inhibitory concentration: 2000 nM
The estimate for compound 4 lay 10-fold (1.00 log units) above the measured number, and the stated range ends above it.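

In this assay compound 2 stays at a limit of the assay and gives no number: the limit of > 15000 nM in this assay, at which 2 of the 4 values shown sit.

Putting cyclohexylmethyl in place of 2,3-dihydro-1,4-benzodioxin-6-yl, on a saturated chain carbon bound to an oxygen next to a carbonyl group, gives an at least 7.5-fold lower number from compound 2 to compound 4 (0.87 log units; beyond the scatter). Among the compounds shown here, compound 4 gives 2000 nM, the only true number in the set. This shows that a change at this place alone can yield a true number in the series, whereas no step can be read among compound 1, compound 2 and compound 3.

The change swaps an aromatic ring of carbon only and a ring with two hetero atoms for one non-aromatic carbon ring, and the compounds shown cannot separate these differences or say which of them matters, or why. On these data alone, a 2-phenylethyl group or a plain cyclohexyl group at the same place would begin to separate them, and it remains open whether the gain in compound 4 would survive with acetyl groups on the sugar hydroxyls or with a free carboxylic acid in place of the methyl ester on the core.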